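Ring-nitrogen methylation and pyridine substituent swap in the series

The compounds below may be only part of what the source reports. "The series", "measured", "known", "first", "only" and "open" are said of these compounds alone.

Measured compounds:
compound 1 `Clc1ccncc1C1=CC2CNCC(C1)C2`: 46%
compound 2 `Fc1ccc(C2=CC3CNCC(C2)C3)cn1`: 104%
compound 3 `CN1CC2C=C(c3ccc(F)nc3)CC(C2)C1`: 22%

In an in vitro functional assay on SH-EP1 cells for agonist activity at Neuronal acetylcholine receptor; alpha4/beta2 (Homo sapiens), read by FLIPR and calcium flux (on this read-out lower numbers stand for smaller maximal responses and higher numbers for larger maximal responses), compound 3 gives the lowest maximal response of the three; the nearest value is that of compound 1 and the furthest that of compound 2. Among the measured compounds shown here, the only step between measured compounds that differ in one place is a number 82 percentage points lower from compound 2 to compound 3 (beyond the scatter), from methyl in place of hydrogen on the amine nitrogen in the ring.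

Compound 4 `COc1ccc(C2=CC3CC(C2)CN(C)C3)cn1` keeps that methylated nitrogen and differs from compound 3 only by methoxy in place of fluoro on an aromatic carbon. For the measured compounds named here, no measured step addresses an exchange of this kind, so the expectation rests on compound 3 alone and on the large drop seen in a number 82 percentage points lower from compound 2 to compound 3 (beyond the scatter) staying in place. The step of a number 3 percentage points higher from compound 3 to compound 4 (within the scatter) is therefore expected to stay within the scatter. Compound 4 is estimated at 25%, with a range from 8% to 50%.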

Compound 4, largest response reached (reported as percent of maximum), in percent of the reference or control that the assay uses: 91%
Compound 4: middle estimate off by 66 percentage points, on the low side, outside the stated range (above it).
By their numbers in this assay, from the lowest: compound 3; then compound 1; then compound 4; then compound 2.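

The step of a number 69 percentage points higher from compound 3 to compound 4 (beyond the scatter) in this assay comes from methoxy in place of fluoro on the aromatic carbon next to the ring nitrogen, so this position can carry a large change in maximal response. With the methylated amine nitrogen kept, compound 4 reaches 91% and shows that methylation does not by itself hold the response low. Nothing available here gives a reason for the change.

On these data alone, whether methoxy behaves the same way with hydrogen on the amine nitrogen stays open. As far as these compounds go, it is also open how an ethoxy group or an amine at this carbon would compare.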